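The source may report more compounds than this note shows. Statements on the series, on what has been measured and on what is new or still open speak of the compounds shown alone.

Three compounds share a thiocarbonyl bearing a sulfur-linked methylene that reaches into a chromone-type core, and all three were tested in a functional assay on SW480 cells (Homo sapiens) for antiproliferative activity, read by MTT assay, with a stated time of 72 h; on this read-out higher numbers stand for weaker inhibition and lower numbers for stronger inhibition. Compound 1 `COc1ccc2occ(CSC(=S)N(C(C)C)C(C)C)c(=O)c2c1` gives 4800 nM in this assay. Compound 3 `COc1ccc2occ(CSC(=S)N3CCCC3)c(=O)c2c1`, which carries pyrrolidin-1-yl in place of diisopropylamino on a thiocarbonyl carbon, gives 4800 nM. The step of no change at the digits printed from compound 1 to compound 3 (within the scatter) therefore shows that swapping these two amine groups on the thiocarbonyl carbon left the antiproliferative read-out where it was.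

Compound 2 `CC(C)N(C(=S)SCc1oc2ccccc2c(=O)c1Cl)C(C)C` has a different core from compound 1; the difference between the two cores is not broken down here. In this assay compound 2 gives 18100 nM, the highest of the three numbers, and its gap to compound 1 and to compound 3 lies beyond the usual scatter.

Compound 4 `O=c1c(Cl)c(CSC(=S)N2CCCC2)oc2ccccc12` has not yet been measured. It differs from compound 2 by pyrrolidin-1-yl in place of diisopropylamino on a thiocarbonyl carbon, the same change that carries compound 1 to compound 3, on the same kind of position. Within the data shown here, because no change at the digits printed from compound 1 to compound 3 (within the scatter) was flat, the writer expects the corresponding step of a 1.0-fold lower number from compound 2 to compound 4 (0.00 log units; within the scatter) to be flat as well, and this expectation rests on that one pair alone, since no other example of the change is at hand. On that basis compound 4 is estimated at 18000 nM in this assay, with a plausible range from 7000 nM to 45000 nM, essentially the value of compound 2 carried over.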

Compound 4, half-maximal inhibitory concentration: 1400 nM
Compound 4: the middle estimate sits 13-fold (1.11 log units) above what was measured, outside the stated range (below it).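

In this assay, replacing diisopropylamino with pyrrolidin-1-yl on a thiocarbonyl carbon gives a 13-fold lower number from compound 2 to compound 4 (1.11 log units; beyond the scatter), and this does not repeat what the same replacement did on the core of compound 1: the same change on two cores in this assay, no change at the digits printed (within the scatter) from compound 1 to compound 3 and a 13-fold lower number (1.11 log units; beyond the scatter) from compound 2 to compound 4, 13-fold (1.11 log units) apart, beyond the scatter of two such steps. This shows that, among these compounds, the size of the step depends on the core carrying it, so a flat result on one core gave no safe reading for the other. It does not show what in the two cores is responsible, and two pairs give no general rule for how the change would behave on any further core.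

The compounds shown leave open whether the large step on the core of compound 2 belongs to pyrrolidin-1-yl in particular or would also appear with another amine on the thiocarbonyl carbon, such as piperidin-1-yl, morpholin-4-yl or dimethylamino. They also leave open how the same replacement would behave on an intermediate core, for example the core of compound 2 with hydrogen in place of its chlorine, which could help show which part of that core goes with the difference.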